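Urea to amide step from compound 2 to compound 3

A few compounds are considered here, and "the series" means these few. Any claim that something is new, unique, unknown or untested is made for them only; others in the source may bear on it.

compound 1 `COc1cc(Cl)cc(-c2nn(-c3cccc(NC(=O)Nc4ccc(Cl)c(C(F)(F)F)c4)c3)cc2-c2ccncc2)c1`: -8%
compound 2 `COc1cc(Cl)cc(-c2nn(-c3cccc(NC(=O)Nc4cccc(C(F)(F)F)c4)c3)cc2-c2ccncc2)c1`: -24%

Going by the values given here, in a functional assay on MCF7 cells (Homo sapiens) for inhibition, read by sulforhodamine B assay, with a stated time of 48 h, tested at 100 uM (on this read-out higher numbers stand for a weaker effect at the one concentration tested and lower numbers for a stronger effect), compound 1 gives -8%, while compound 2 gives -24% and so stands lowest of the two numbers; the only measured step is a number 16 percentage points lower from compound 1 to compound 2 (beyond the scatter). Compound 3 `COc1cc(Cl)cc(-c2nn(-c3cccc(NC(=O)c4cccc(C(F)(F)F)c4)c3)cc2-c2ccncc2)c1` differs from compound 2 by 3-(trifluoromethyl)phenyl in place of (3-(trifluoromethyl)phenyl)amino on a carbonyl carbon. Among the compounds with values here, no measured step touches the carbonyl carbon or its amide-type nitrogen, so nothing bears directly on this change, and the expectation is a step of a number 9 percentage points higher from compound 2 to compound 3 (within the scatter) that may well stay within the scatter. Compound 3 is therefore estimated at -15%, with a range from -40% to 10%.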

Compound 3, a percentage reported as activity, at one concentration (the size of the read-out at that concentration, not a potency): 38%
Compound 3: middle estimate off by 53 percentage points, on the low side, and the stated range ends below it.
By their numbers in this assay, from the lowest: compound 2; then compound 1; then compound 3.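

In this assay, 3-(trifluoromethyl)phenyl in place of (3-(trifluoromethyl)phenyl)amino on the carbonyl carbon gives a number 62 percentage points higher from compound 2 to compound 3 (beyond the scatter), so this position is sensitive to the change from urea to amide, which the chloro step could not show. The comparison with the chloro-bearing urea points the same way, with a number 46 percentage points higher from compound 1 to compound 3 (beyond the scatter). No measurement available here accounts for this loss of effect. Still open, going by these compounds, is whether the step follows the amino nitrogen itself, which a methylene group or an oxygen atom in its place on the carbonyl carbon would address.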